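The source may hold more compounds than are shown below. What is called first, only, known or untested is meant among the compounds shown, and "the series" means these compounds.

Compound 1, `O=C(CCCCCCc1ccccc1)c1ncno1`, sets the reference point: in an assay for inhibition of Fatty-acid amide hydrolase 1 (Rattus norvegicus), at pH 9.0 (on this read-out lower numbers stand for stronger inhibition and higher numbers for weaker inhibition), compound 1 gives 1 nM. Compound 2, `O=C(CCCCCCc1ccccc1)c1ncc(-c2ccco2)s1`, shares the seven-carbon phenylalkyl ketone chain but carries a different five-membered aromatic ring at the ketone, and in this assay compound 2 gives 1500 nM. Within the data shown here, of the two numbers known, compound 2 therefore holds the highest, and its nearest neighbour, compound 1, sits far below it, by a gap that lies well beyond the usual scatter.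

Compound 3, `O=C(CCCCCCc1ccccc1)c1ncc(-c2cccs2)s1`, has not yet been measured. It differs from compound 2 in a single place: thiophen-2-yl in place of furan-2-yl on an aromatic carbon. The heterocyclic ring at the ketone and the chain stay as they are in compound 2.

Among the measured compounds shown here, no step between measured compounds addresses a swap of this kind, so the expectation rests on the value of compound 2 alone. The change is small in what it counts, and the number for compound 3 is expected to move from compound 2 by a 1.5-fold lower number from compound 2 to compound 3 (0.18 log units; within the scatter), a step that would stay within the scatter rather than reach beyond it. In this assay compound 3 is accordingly estimated at 1000 nM, with a likely range from 300 nM to 4000 nM.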

Compound 3, inhibition constant: 2000 nM
Estimate against measurement, compound 3: 2.0-fold (0.30 log units) below, within the range that was stated.
By their numbers in this assay, from the lowest: compound 1; then compounds 2 and 3 (each within the scatter of the next).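

Among these compounds, the exchange of furan-2-yl for thiophen-2-yl, on the aromatic carbon next to the ring sulfur, gives a 1.3-fold higher number from compound 2 to compound 3 (0.12 log units; within the scatter) in this assay, and this is the only reading of a swap at this position. The two groups match in heavy atoms, in hydrogen-bond donors and acceptors and in charge, and they differ only in the oxygen or sulfur of the ring, so on this core and chain the two cannot be told apart in this assay. Compound 2 alone could not show this, since a single value says nothing about how a position answers an exchange. Nothing at hand explains why the two groups read alike.

The compounds shown carry only these two five-membered rings at this carbon, so it remains open whether a phenyl ring, a carboxylic acid or an aminomethyl group there would read differently in this assay. As far as these compounds go, it is also open how a plain hydrogen at this carbon would read with the same core and chain, which would show what either ring contributes.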